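Cyclohexylmethyl in Place of Difluorobenzyl: Cytotoxicity Outlook

The compounds below may be only part of what the source reports. "The series", "measured", "known", "first", "only" and "open" are said of these compounds alone.

In an ADME assay on 2209-23 cells (Homo sapiens) for cytotoxicity, read by WST assay (on this read-out higher numbers stand for lower toxicity in this test and lower numbers for higher toxicity in this test), three members of one series have been measured so far. Compound 1 `CC(=O)Nc1ccc2c(c1)S(=O)(=O)C=C(c1c(O)c3cc(F)ccc3n(Cc3ccc(F)cc3)c1=O)N2` gives > 50000 nM, which is a limit of the assay rather than a number. Compound 2 `CS(=O)(=O)c1ccc2c(c1)S(=O)(=O)C=C(c1c(O)c3cc(F)ccc3n(Cc3ccc(F)cc3)c1=O)N2` gives > 50000 nM, again a limit. Compound 3 `CS(=O)(=O)Nc1ccc2c(c1)S(=O)(=O)C=C(c1c(O)c3cc(F)ccc3n(Cc3ccc(F)c(F)c3)c1=O)N2` gives > 50000 nM, a limit as well. Among the measured compounds shown here, the single one-place step among them, a step that the two limits leave unreadable from compound 1 to compound 2, cannot be sized, since both of its ends are limits. Compound 3 therefore stands exactly where the whole set stands, at the limit of > 50000 nM in this assay, at which 3 of the 3 values shown sit.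

Compound 4 `CS(=O)(=O)Nc1ccc2c(c1)S(=O)(=O)C=C(c1c(O)c3cc(F)ccc3n(CC3CCCCC3)c1=O)N2` differs from compound 3 in one place: cyclohexyl in place of 3,4-difluorophenyl on a saturated chain carbon bound to an aromatic nitrogen. For the measured compounds named here, the only measured step, a step that the two limits leave unreadable from compound 1 to compound 2, is unreadable and sits elsewhere on the shared core, so no measured step bears directly on the change from compound 3 to compound 4. With every measured compound resting at the limit, no movement beyond the scatter is expected in this assay, and compound 4 is expected to be reported as a limit too. The step expected in this assay is a step that the limit leaves unreadable from compound 3 to compound 4. Compound 4 is accordingly estimated at 80000 nM, with a range from 30000 nM to 250000 nM.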

Compound 4, half-maximal cytotoxic concentration: > 50000 nM
Compound 4: no number, only a limit (the forecaster's own chance of this, stated with the estimate: 85%); the middle value is on the limit's open side.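

In this assay, no new step can be read between compound 3 and compound 4, because both are reported only as limits and not as numbers: the limit of > 50000 nM in this assay, at which 4 of the 4 values shown sit.

The compounds shown leave open whether cyclohexyl and 3,4-difluorophenyl differ at all in this read-out, and at what concentration, if any, these four compounds would become toxic to the cells.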